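The source may hold more compounds than are shown below. What is called first, only, known or untested is meant among the compounds shown, and "the series" means these compounds.

Values so far in a functional assay for inhibition, with Rattus norvegicus as the target (a lower number here means a stronger inhibitor, a higher number a weaker inhibitor), are these:

- compound 1 `CCOc1c(C(C)O[Si](C)(C)C(C)(C)C)c(OC(C)=O)c2ccccc2c1OC` gives 23900 nM
- compound 2 `CCCCc1cc(OC)c2occc2c1OC(C)=O` gives 110 nM
- compound 3 `CCCCc1cc(OC)c2occc2c1O` gives 11900 nM

Compound 3 stands with compound 1 at the high end of the three numbers, the two within the scatter of each other, while compound 2 lies far lower. Compound 4 `CCCCc1c(CCCC)c(OC)c2occc2c1O` differs from compound 3 by butyl in place of hydrogen on an aromatic carbon, ortho to the butyl group already present. For the measured compounds named here, the one measured step, a 110-fold higher number from compound 2 to compound 3 (2.03 log units; beyond the scatter), is hydrogen in place of acetyl on an oxygen, a different change, and bears only indirectly. Going by the values given here, no measured step covers this change, so no shift beyond the scatter is expected in this assay. For compound 4 the expected step is a 1.3-fold lower number from compound 3 to compound 4 (0.12 log units; within the scatter), with only a slight lean to a lower number. The estimated value for compound 4 is 9000 nM, with an expected range from 2500 nM to 30000 nM overall.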

Compound 4, half-maximal inhibitory concentration: 1150 nM
Compound 4: the middle estimate sits 7.8-fold (0.89 log units) above what was measured; measured number outside the range, below it.
By their numbers in this assay, from the lowest: compound 2; then compound 4; then compounds 3 and 1 (each within the scatter of the next).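

In this assay, butyl in place of hydrogen on the aromatic carbon ortho to a butyl group and ortho to a methoxy group gives a 10-fold lower number from compound 3 to compound 4 (1.01 log units; beyond the scatter), so a change on the ring carbon moves the number beyond the scatter while the hydroxy group stays free. For the compounds shown here, until now, the only large step was at the oxygen, between acetyl and hydrogen. No available measurement bears on the reason for this step.

Open, from the compounds shown here alone, is whether a shorter chain such as methyl, a longer chain such as hexyl, or an amine at this carbon would give a similar number. Also open, going by these compounds, is whether acetyl on the oxygen of compound 4 would lower the number further.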